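The source may hold more compounds than are shown below. What is called first, only, known or untested is meant among the compounds shown, and "the series" means these compounds.

Measured compounds:
Compound 1 `C[C@@H](O)[C@H]1C(=O)N2C(C(=O)OCC(F)(F)F)=C(S[C@@H]3CN[C@H](C(=O)Nc4cccc(C(=O)O)c4)C3)[C@H](C)[C@H]12` in an ADME assay for metabolic stability, read by LC-MS, with a stated time of 3 h, at pH 6.5, tested at 50 uM (on this read-out lower numbers stand for a less stable compound and higher numbers for a more stable compound), gives > 95%, which is a limit of the assay rather than a number.
Compound 2 `C[C@@H](O)[C@H]1C(=O)N2C(C(=O)OCOC(=O)OC3CCCCC3)=C(S[C@@H]3CN[C@H](C(=O)Nc4cccc(C(=O)O)c4)C3)[C@H](C)[C@H]12` in this assay gives > 95%, again a limit rather than a number.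

Compound 2 thus stands at the limit, where both shown values sit (the limit of > 95% in this assay, at which 2 of the 2 values shown sit). Compound 3 `CC(C)C(=O)OCOC(=O)C1=C(S[C@@H]2CN[C@H](C(=O)Nc3cccc(C(=O)O)c3)C2)[C@H](C)[C@@H]2[C@@H]([C@@H](C)O)C(=O)N12` differs from compound 2 by isopropyl in place of cyclohexyloxy on a carbonyl carbon. For the measured compounds named here, the only measured step, a step that the two limits leave unreadable from compound 1 to compound 2, runs between two limits and so has no readable size, leaving nothing that speaks for a shift. No step beyond the usual scatter is therefore expected for a number at least 2 percentage points lower from compound 2 to compound 3 (that floor lies within the scatter). Compound 3 is estimated at 93%, within a range from 78% to 99%, most likely reported once more only as a limit.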

Compound 3, percent of the compound remaining: > 95%
Compound 3: no number, only a limit (the forecaster's own chance of this, stated with the estimate: 65%); middle value at least 2 percentage points from the limit.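

No step among compound 1, compound 2 and compound 3 can be read in this assay, because all of them sit at one limit: the limit of > 95% in this assay, at which 3 of the 3 values shown sit.

As far as these compounds go, whether these three compounds truly differ in stability remains open.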